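Swapping the Amine Partner on a Thiocarbonyl Carbon

The compounds below may be only part of what the source reports. "The series", "measured", "known", "first", "only" and "open" are said of these compounds alone.

Three measured compounds share one core and differ only in the group bound to a thiocarbonyl carbon. In a functional assay on A-375 cells (Homo sapiens) for antiproliferative activity, read by CCK-8 assay, with a stated time of 72 h, tested at 2 uM (on this read-out higher numbers stand for a stronger effect at the one concentration tested and lower numbers for a weaker effect), compound 2 `Nc1ccccc1NC(=O)c1ccc(CSC(=S)N2CCCc3ccccc32)cc1` gives 26.5%, the highest of the three numbers. Compound 3 `Nc1ccccc1NC(=O)c1ccc(CSC(=S)N(Cc2ccccc2)Cc2ccccc2)cc1` gives 10.9% and compound 1 `Nc1ccccc1NC(=O)c1ccc(CSC(=S)N2CCN(C(c3ccccc3)c3ccccc3)CC2)cc1` gives 8.7%, both beyond the scatter below compound 2. Compound 4 `CN1CCN(C(=S)SCc2ccc(C(=O)Nc3ccccc3N)cc2)CC1` has not been measured. It differs from compound 2 in one place: 4-methylpiperazin-1-yl in place of 1,2,3,4-tetrahydroquinolin-1-yl on a thiocarbonyl carbon. Within the data shown here, no measured pair shows exactly this change, but compounds 1 and 3 show that other groups at this position give lower numbers than compound 2. A decrease of a number 14.5 percentage points lower from compound 2 to compound 4 (beyond the scatter) is therefore expected, probably beyond the scatter. Compound 4 is estimated to give 12%, within a range from 0% to 28%.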

Compound 4, a percentage reported as inhibition, at one concentration (the size of the read-out at that concentration, not a potency): 36.6%
Beside the measured number, compound 4's estimate is 24.6 percentage points below it, and the stated range ends below it.
By their numbers in this assay, from the lowest: compounds 1 and 3 (each within the scatter of the next); then compound 2; then compound 4.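

In this assay, 4-methylpiperazin-1-yl in place of 1,2,3,4-tetrahydroquinolin-1-yl on a thiocarbonyl carbon gives a number 10.1 percentage points higher from compound 2 to compound 4 (beyond the scatter). This modest step shows that this position can carry a smaller group with no aromatic ring and still give a higher number than compound 2. Nothing available here explains the rise. The compounds shown leave open whether the step follows the extra ring nitrogen or its methyl. Piperidin-1-yl, or an ethyl group in place of that methyl, would help separate these two possibilities.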